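A few compounds are considered here, and "the series" means these few. Any claim that something is new, unique, unknown or untested is made for them only; others in the source may bear on it.

Measured so far:
compound 1 `COc1ccccc1N1CCN(CCCNC(=O)NN(Cc2ccccc2)c2ccc(Cl)cc2Cl)CC1` gives 15 nM in an assay on CHO cells for displacement of a labelled ligand from D(4) dopamine receptor (Homo sapiens), read by radioligand binding; a lower number here means a stronger inhibitor, a higher number a weaker inhibitor
compound 2 `COc1ccc(N(Cc2ccccc2)NC(=O)NCCCN2CCN(c3ccccc3OC)CC2)cc1` gives 1.7 nM in this assay

Compound 2 holds the lower of the two numbers in this assay; the only step shown is an 8.8-fold lower number from compound 1 to compound 2 (0.95 log units; beyond the scatter). Compound 3 `C=CCN(NC(=O)NCCCN1CCN(c2ccccc2OC)CC1)c1ccc(OC)cc1` differs from compound 2 by vinyl in place of phenyl on a saturated chain carbon bound to a nitrogen on an aromatic ring. For the measured compounds named here, no measured step touches this position; the step from compound 1 to compound 2 concerns the aryl group on the same nitrogen and gives no guide to the chain. Little change beyond the scatter is expected, so the step from compound 2 to compound 3 is estimated as a 2.4-fold higher number from compound 2 to compound 3 (0.37 log units; beyond the scatter). Compound 3 is thus expected near 4 nM, within 1.2 nM to 15 nM.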

Compound 3, inhibition constant: 61 nM
The estimate for compound 3 lay 15-fold (1.18 log units) below the measured number, outside the stated range (above it).
By their numbers in this assay, from the lowest: compound 2; then compound 1; then compound 3.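

Vinyl in place of phenyl at this position gives a 36-fold higher number from compound 2 to compound 3 (1.55 log units; beyond the scatter) in this assay, so this site on a saturated chain carbon bound to a nitrogen on an aromatic ring is far from indifferent to the change. With the aromatic ring of the benzyl group replaced, the low number of compound 2 is not retained by allyl. No evidence at hand accounts for this step.

Still open, as far as these compounds go, is whether a ring is what counts here: a cyclohexylmethyl group or a phenethyl group would separate ring, aromatic ring and chain length. A plain propyl group would likewise test the double bond of allyl.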